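Ester-to-amide swap at the carbonyl in a biphenyl series

The source may hold more compounds than are shown below. What is called first, only, known or untested is meant among the compounds shown, and "the series" means these compounds.

Measured compounds in an assay on COS-7 cells for inhibition of patatin-like phospholipase domain-containing protein 2 (Mus musculus), tested at 200 uM; a lower number here means less inhibition, a higher number more inhibition at the concentration tested (going by the name of the read-out):
- compound 1 `CCOC(=O)c1cccc(-c2ccc(OCC)cc2)c1`: 87%
- compound 2 `CCOc1ccc(-c2cccc(S(=O)(=O)N(C)C)c2)cc1`: 63%
- compound 3 `CCOc1ccc(-c2cccc(C(=O)OCCOC)c2)cc1`: 89%

Compound 3 gives the highest of the three numbers; compound 1 sits nearest, and the gap a number 2 percentage points higher from compound 1 to compound 3 (within the scatter) lies within the scatter, so no order between compound 1 and compound 3 is claimed. Compound 2 is the furthest from compound 3, shown by a number 26 percentage points higher from compound 2 to compound 3 (beyond the scatter).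

The next compound, compound 4 `CCOc1ccc(-c2cccc(C(=O)N3CCCC3)c2)cc1`, is not yet measured. Relative to compound 3 its change is pyrrolidin-1-yl in place of 2-methoxyethoxy on a carbonyl carbon.

For the measured compounds named here, two measured steps bear on this. The step of a number 2 percentage points higher from compound 1 to compound 3 (within the scatter) shows that lengthening the ester alkoxy side by a methoxy does nothing beyond the scatter, so the part that leaves carries little weight on its own. The step of a number 24 percentage points lower from compound 1 to compound 2 (beyond the scatter) is the closer precedent: there the ester gave way to a nitrogen-bearing group carrying two methyls, and the number fell modestly. Going by the values given here, compound 4 replaces the ester oxygen with a ring nitrogen, which resembles that change more than the one from compound 1 to compound 3. A modest fall is therefore expected, smaller than or similar to a number 24 percentage points lower from compound 1 to compound 2 (beyond the scatter).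

For compound 4 the expected value in this assay is 72%, with a range from 52% to 90%, meaning an expected step of a number 17 percentage points lower from compound 3 to compound 4 (beyond the scatter).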

Compound 4, a percentage reported as inhibition, at one concentration (the size of the read-out at that concentration, not a potency): 53%
Compound 4: middle estimate off by 19 percentage points, on the high side, and the stated range covers the measured number.
By their numbers in this assay, from the lowest: compounds 4 and 2 (each within the scatter of the next); then compounds 1 and 3 (each within the scatter of the next).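

Working notes: in this assay, the group on the carbonyl carbon matters more than the ester side chain alone suggested, since adding a methoxy to the ester gave only a number 2 percentage points higher from compound 1 to compound 3 (within the scatter), whereas pyrrolidin-1-yl in place of 2-methoxyethoxy gives a number 36 percentage points lower from compound 3 to compound 4 (beyond the scatter), and in place of ethoxy gives a number 34 percentage points lower from compound 1 to compound 4 (beyond the scatter). The step of a number 10 percentage points lower from compound 2 to compound 4 (within the scatter) leaves the (pyrrolidin-1-yl)carbonyl and dimethylsulfamoyl groups unseparated, so among these four compounds the two esters, compound 1 and compound 3, form an upper pair and compound 2 and compound 4 a lower pair, with no compound going against that split. Nothing measured here accounts for the size of the amide step.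

The single change to compound 4 brings in both a ring and an amide nitrogen, so the compounds shown cannot say which of the two goes with the lower number; an open-chain dimethylamide at the same carbonyl carbon would separate them. Also open, as far as these compounds go, is how a secondary amide, with its amide hydrogen, or a free carboxylic acid at this carbonyl carbon would read in this assay.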